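Methyl in place of chloro at the carboxy end

This account rests on a few compounds, and the source may have more. Where it says the series, first, only, none or still open, it means among the compounds named here.

For the measured compounds named here, in an assay on HEK293 cells for positive allosteric modulation of metabotropic glutamate receptor 2 (Rattus norvegicus), read by thallium flux, with a stated time of 2.5 min (a lower number here means that less compound is needed, a higher number that more compound is needed for the effect), compound 1 `Cc1c(OCCCCOc2ccc(C(=O)O)cc2Cl)ccc(C(=O)CC2CCCC2)c1O` gives 237 nM, the highest of the two numbers measured so far. Its nearest measured neighbour, compound 2 `Cc1c(OCCCCOc2ccc(C(=O)O)cc2Cl)ccc(C(=O)CC(C)C)c1O`, gives 96 nM in this assay; the step of a 2.5-fold lower number from compound 1 to compound 2 (0.39 log units; beyond the scatter) is the only one recorded, and it concerns the group on the saturated chain carbon bound to the carbonyl carbon, at the opposite end of the shared core from the carboxy group.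

Compound 3 `Cc1cc(C(=O)O)ccc1OCCCCOc1ccc(C(=O)CC2CCCC2)c(O)c1C` differs from compound 1 by methyl in place of chloro on an aromatic carbon. Going by the values given here, no measured step touches this aromatic carbon or the 4-carboxy-2-chlorophenyl part at all, so the recorded step offers no guidance beyond showing that a single small substitution elsewhere shifts this assay by a modest amount. Among the compounds with values here, with no direct precedent, the expectation for compound 3 is a step of a 1.0-fold higher number from compound 1 to compound 3 (0.01 log units; within the scatter) that stays within the scatter, in no settled direction. Compound 3 is therefore estimated at 240 nM in this assay, with a range from 100 nM to 600 nM that allows for a modest move either way.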

Compound 3, half-maximal effective concentration: 608 nM
Compound 3: middle estimate off by 2.5-fold (0.40 log units), on the low side, outside the stated range (above it).
By their numbers in this assay, from the lowest: compound 2; then compound 1; then compound 3.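

Methyl in place of chloro on this aromatic carbon, ortho to a large group and meta to a carboxy group, gives the first reading at this part of the series: in this assay the change is a step of a 2.6-fold higher number from compound 1 to compound 3 (0.41 log units; beyond the scatter) and so this position responds to the exchange of one heavy atom for another. Its size is printed as modest, like that of the change on the saturated chain carbon bound to a carbonyl carbon (a 2.5-fold lower number from compound 1 to compound 2 (0.39 log units; beyond the scatter)), but the number goes up here and down there, so changes in both places now register in this assay and chloro is the better of the two groups tried on this aromatic carbon. The exchange leaves the counts of hydrogen-bond donors and acceptors and the net charge as they were, and nothing measured here accounts for the shift.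

On these data alone, whether the same exchange moves the number by a similar amount with isopropyl in place of cyclopentyl remains open. Also open, as far as these compounds go, is how fluoro, bromo, methoxy or plain hydrogen on this aromatic carbon would read, and with them whether the higher number reflects the loss of chloro or the arrival of methyl.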